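Biphenyl esters and carbamates: alkyl extension and expected inhibition

A few compounds are considered here, and "the series" means these few. Any claim that something is new, unique, unknown or untested is made for them only; others in the source may bear on it.

Measured so far:
Compound 1, `CCOC(=O)c1cccc(-c2ccc(OCC)cc2)c1`, in an assay on COS-7 cells for inhibition of patatin-like phospholipase domain-containing protein 2 (Mus musculus), tested at 200 uM (a higher number here means more inhibition at the concentration tested (going by the name of the read-out), a lower number less inhibition), gives 87%.
Compound 2, `CCOC(=O)c1cccc(-c2ccc(OC)cc2)c1`, gives 77%.
Compound 3, `CCOC(=O)Nc1cccc(-c2ccc(N(C)C)cc2)c1`, gives 93%.

Among the measured compounds shown here, the one pair that differs in a single place is compound 2 and compound 1: methyl in place of hydrogen on a saturated chain carbon bound to an oxygen on an aromatic ring. This gave a number 10 percentage points higher from compound 2 to compound 1 (within the scatter), so the two values cannot be told apart here. Compound 3 carries the highest number of the three; its gap to compound 1 is within the scatter, only its gap to compound 2 lies beyond it, so the number for compound 3 is higher than that of compound 2, while it cannot be told apart from that of compound 1. The difference between the core of compound 3 and the core of compound 2 is not broken down here.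

Compound 4, `CC(C)OC(=O)Nc1cccc(-c2ccc(N(C)C)cc2)c1`, has not been measured. It stands to compound 3 as methyl in place of hydrogen on a saturated chain carbon bound to an oxygen next to a carbonyl group and a saturated chain carbon. This is the same kind of change as that from compound 2 to compound 1, not the same one: there the place was on a saturated chain carbon bound to an oxygen on an aromatic ring, here it is on a saturated chain carbon bound to an oxygen next to a carbonyl group and a saturated chain carbon.

For compound 4 the expected step is a number 2 percentage points lower from compound 3 to compound 4 (within the scatter), resting on the small size of a number 10 percentage points higher from compound 2 to compound 1 (within the scatter) and on compound 3 already giving 93%, which leaves little room upward. Compound 4 is thus estimated at 91%, expected between 78% and 99%.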

Compound 4, a percentage reported as inhibition, at one concentration (the size of the read-out at that concentration, not a potency): 69%
Compound 4: the middle estimate sits 22 percentage points above what was measured; measured number outside the range, below it.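

In this assay, the added methyl gives a number 24 percentage points lower from compound 3 to compound 4 (beyond the scatter), and set beside the earlier step, this change does not carry over with a constant size or direction from one core to the other: the same change on two cores in this assay, a number 10 percentage points higher (within the scatter) from compound 2 to compound 1 and a number 24 percentage points lower (beyond the scatter) from compound 3 to compound 4, 34 percentage points apart, beyond the scatter of two such steps

The comparison does not separate the core from the place of the change: in one pair the methyl sits on a saturated chain carbon bound to an oxygen on an aromatic ring, and in the other on a saturated chain carbon bound to an oxygen next to a carbonyl group and a saturated chain carbon. With one pair for each case, and with each read-out taken at a single concentration, the data give no rule for the size of this step on any further core, and they offer no reason for the difference.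

The compounds shown leave open whether a methoxycarbonyl or a tert-butoxycarbonyl in place of the ethoxycarbonyl of compound 3 would follow the step seen with the isopropoxycarbonyl of compound 4. Also open, as far as these compounds go, is how an isopropoxy group in place of the ethoxy group of compound 1 would read, which would test the same change again at that place.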